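A few compounds are considered here, and "the series" means these few. Any claim that something is new, unique, unknown or untested is made for them only; others in the source may bear on it.

Working notes on the series. In an ADME assay on A549 cells (Homo sapiens) for inhibition, read by MTT assay (on this read-out lower numbers stand for stronger inhibition of growth and higher numbers for weaker inhibition of growth), compound 1 (`Cc1ccc(O)c(C(=O)/C=C/c2cn(-c3ccc(F)cc3)nc2-c2sc(C)nc2C)c1`) gives 47.8 ug/mL and compound 2 (`Cc1nc(C)c(-c2nn(-c3ccc(F)cc3)cc2C2CC(c3cc(Br)ccc3O)=NN2)s1`) gives 81.4 ug/mL on the same read-out. These two values lie within the scatter of each other, so compound 2 stands level with compound 1, and no ranking can be drawn from them. Among the measured compounds shown here, no measured pair differs in one place only, so no measured step is available as a guide.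

Compound 3 (`Cc1nc(C)c(-c2nn(-c3ccc(F)cc3)cc2C2CC(c3cc(Cl)c(C)cc3O)=NN2)s1`) keeps the rest of compound 2 and carries 5-chloro-2-hydroxy-4-methylphenyl in place of 5-bromo-2-hydroxyphenyl on a carbon with a double bond to nitrogen. The hydroxyl-bearing aromatic ring stays, and the exchange is limited to this one group. In this assay no step beyond the scatter is expected, and no direction is favoured. The estimate corresponds to an expected step of a 1.2-fold lower number from compound 2 to compound 3 (0.07 log units; within the scatter) and should be read as no real change. Compound 3 is expected at 70 ug/mL (estimated range 35 ug/mL to 140 ug/mL).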

Compound 3, concentration for 50% growth inhibition: 146 ug/mL
For compound 3 the middle estimate is 2.1-fold (0.32 log units) below the measured one, and the stated range ends below it.
By their numbers in this assay, from the lowest: compounds 1, 2 and 3 (each within the scatter of the next, the first and the last beyond it).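

In this assay the series now has its first pair differing in one place: 5-chloro-2-hydroxy-4-methylphenyl in place of 5-bromo-2-hydroxyphenyl gives a 1.8-fold higher number from compound 2 to compound 3 (0.25 log units; within the scatter) and so shows no real difference. Among the compounds shown here, this is the first direct reading at this place, on a carbon with a double bond to nitrogen of the five-membered non-aromatic ring with 2 nitrogen, and it shows that this exchange of one substituted hydroxyl-bearing aromatic ring for another leaves the read-out level within the scatter. No evidence at hand bears on this result.

The chlorine and the methyl enter together in this single step, so their separate contributions remain unresolved, and a step within the scatter says nothing about how far the position can be changed. Also open, as far as these compounds go, is how the read-out responds to an amine or a carboxylic acid on this aromatic ring, or to a saturated cyclohexyl ring in place of the whole hydroxyl-bearing aromatic ring.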